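A few compounds are considered here, and "the series" means these few. Any claim that something is new, unique, unknown or untested is made for them only; others in the source may bear on it.

Of the compounds shown here, two have been measured in an assay on isolated protein for inhibition of tyrosine-protein phosphatase non-receptor type 13 (Homo sapiens), read by spectrophotometry; on this read-out lower numbers stand for stronger inhibition and higher numbers for weaker inhibition. Compound 1 `CCCNC(=O)COc1ccc2cc(C(O)(C(F)(F)F)C(F)(F)F)c(O)cc2c1` gives only a limit in this assay, > 20000 nM. Compound 2 `O=C(COc1ccc2cc(C(O)(C(F)(F)F)C(F)(F)F)c(O)cc2c1)Nc1ccc(-c2ccccc2)cc1` gives 2800 nM in this assay.

Compound 1 therefore stands at the limit of this assay (the limit of > 20000 nM in this assay, at which 1 of the 2 values shown sits), so nothing more than a ceiling is known for it. Among the compounds with values here, the only measured step, an at least 7.1-fold lower number from compound 1 to compound 2 (0.85 log units; beyond the scatter), came from putting 4-phenylphenyl in place of propyl on an amide-type nitrogen. The unmeasured compound 3 `Oc1cc2ccccc2cc1C(O)(C(F)(F)F)C(F)(F)F` differs from compound 1 by hydrogen in place of (propylcarbamoyl)methoxy on an aromatic carbon. This takes away the (propylcarbamoyl)methoxy group entirely, whereas the measured step only exchanged what sits on its amide-type nitrogen, so that step bears on it only loosely. With compound 1 already at the limit, the step that the limit leaves unreadable from compound 1 to compound 3 is expected to stay within the scatter or move toward weaker inhibition. Compound 3 is expected to give 30000 nM, between 8000 nM and 120000 nM, most likely again only as a limit.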

Compound 3, half-maximal inhibitory concentration: 128000 nM
For compound 3 the middle estimate is 4.3-fold (0.63 log units) below the measured one; measured number outside the range, above it.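

No step can be read from compound 1 to compound 3, because compound 1 has only a limit in this assay, not a number: the limit of > 20000 nM in this assay, at which 1 of the 3 values shown sits.

The compounds shown leave open how large a change in inhibition comes with losing the (propylcarbamoyl)methoxy group, and in which direction.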